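Methyl for methoxy in a succinimide-ethoxy series: stability notes

The compounds below may be only part of what the source reports. "The series", "measured", "known", "first", "only" and "open" are said of these compounds alone.

Three compounds of the series have been run in an ADME assay on liver (Homo sapiens) for metabolic stability, read by LC-MS, using microsomes and NADPH; a higher number here means that more of the compound is left, a lower number that less of the compound is left. Compound 1 `CCCN(Cc1ccc(OCCn2c(=O)ccn(C)c2=O)c(C)c1)C(CC(=O)O)c1ccc(Cl)cc1` gives 30%, and compound 2 `CCCN(Cc1ccc(OCCn2c(=O)ccn(C)c2=O)c(OC)c1)C(CC(=O)O)c1ccc(Cl)cc1` gives 61% in this assay. Compound 3 `COc1cc(CN(CC(C)C)C(CC(=O)O)c2ccc(Cl)c(F)c2)ccc1OCCN1C(=O)CCC1=O` gives 76%, the highest of the three; its distance from compound 2 and from compound 1 is beyond the scatter in both cases. How the core of compound 3 differs from that of compound 2 is not broken down here.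

One change recurs. Between compound 2 and compound 1 it is methyl in place of methoxy on an aromatic carbon and it produced a number 31 percentage points lower from compound 2 to compound 1 (beyond the scatter). Compound 4 `Cc1cc(CN(CC(C)C)C(CC(=O)O)c2ccc(Cl)c(F)c2)ccc1OCCN1C(=O)CCC1=O` has not been measured; it stands to compound 3 as compound 1 stands to compound 2, the change being (methyl in place of methoxy on an aromatic carbon). The two settings are the same kind of change rather than the same: in compound 2 the carbon is ortho to a large group, whereas in compound 3 it is ortho to a 2-(2,5-dioxopyrrolidin-1-yl)ethoxy group, both being meta to a large group.

The expectation for compound 4 rests on a single earlier instance, so it is taken as a loss of similar size, estimated as a number 31 percentage points lower from compound 3 to compound 4 (beyond the scatter). With compound 3 at 76% as the starting point, compound 4 is expected to give about 45% in this assay, with a likely range from 25% to 65%.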

Compound 4, percent of the compound remaining: 63%
The estimate for compound 4 lay 18 percentage points below the measured number, within the range that was stated.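

On the core of compound 3, methyl in place of methoxy again lowers the number in this assay, with a number 13 percentage points lower from compound 3 to compound 4 (beyond the scatter). The direction of the change therefore holds on both cores, whereas its size does not carry over: the same change on two cores in this assay, a number 31 percentage points lower (beyond the scatter) from compound 2 to compound 1 and a number 13 percentage points lower (beyond the scatter) from compound 3 to compound 4, 18 percentage points apart, beyond the scatter of two such steps These are only two instances, and the two cores differ in more than one place, so the pair shows neither a general rule for this series nor which difference between the cores goes with the smaller loss.

The compounds shown leave open how other groups on this aromatic carbon, such as ethoxy, fluorine or plain hydrogen, would read in this assay, since methoxy and methyl are the only two groups seen there. Also open, on these data alone, is whether the size of the step follows the 2-(2,5-dioxopyrrolidin-1-yl)ethoxy group, the propyl or 2-methylpropyl chain on the amine nitrogen, or the fluorine on the chlorinated aromatic ring, and a matched pair changing only one of these parts at a time would be needed to separate them.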